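The source may report more compounds than this note shows. Statements on the series, on what has been measured and on what is new or still open speak of the compounds shown alone.

This account concerns three compounds that share a core and carry a sulfonyl group on it. Compound 1, `N#Cc1cccc(S(=O)(=O)c2cnc3c(F)cccc3c2-c2ccccc2F)c1`, and compound 2, `O=S(=O)(c1cc(F)cc(F)c1)c1cnc2c(F)cccc2c1-c1ccc(Cl)cc1`, have both been measured in an ADME assay on microsomes from liver (Homo sapiens) for metabolic stability, tested at 2.5 uM; on this read-out lower numbers stand for slow clearance and higher numbers for fast clearance. In this assay compound 1 gives 0.66 mL/min, and compound 2 gives 0.73 mL/min. Compound 2 stands alongside compound 1: the two numbers lie within the usual scatter of each other, so nothing separates them. Compound 3, `N#Cc1cccc(S(=O)(=O)c2cnc3c(F)cccc3c2-c2ccc(Cl)cc2)c1`, has not yet been measured in this assay. It differs from compound 2 in one place: 3-cyanophenyl in place of 3,5-difluorophenyl on a sulfonyl sulfur. The 3-cyanophenyl that enters is the same group that compound 1 carries on its sulfonyl sulfur, and compound 1 gives 0.66 mL/min, a number that sits beside that of compound 2. Among the measured compounds shown here, no step between measured compounds is available for this change, so the expectation rests only on the two measured values. Compound 3 is therefore expected to stay close to compound 2, with a step of a 1.0-fold lower number from compound 2 to compound 3 (0.02 log units; within the scatter) that is expected to remain within the scatter. The estimate for compound 3 is 0.7 mL/min, with an expected range from 0.4 mL/min to 1.2 mL/min.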

Compound 3, intrinsic clearance in a liver preparation (reported as CLH), per the amount of preparation that the assay uses: 0.08 mL/min
For compound 3 the middle estimate is 8.8-fold (0.94 log units) above the measured one; measured number below the stated range.
By their numbers in this assay, from the lowest: compound 3; then compounds 1 and 2 (each within the scatter of the next).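

In this assay, the sulfonyl sulfur turns out to be a position where the substituent can matter: 3-cyanophenyl in place of 3,5-difluorophenyl gives a 9.1-fold lower number from compound 2 to compound 3 (0.96 log units; beyond the scatter) when 4-chlorophenyl sits on the aromatic carbon. The 3-cyanophenyl group does not set the number alone, since compound 1 also carries it on the sulfonyl sulfur, and 4-chlorophenyl in place of 2-fluorophenyl on the aromatic carbon gives an 8.3-fold lower number from compound 1 to compound 3 (0.92 log units; beyond the scatter) with that group held fixed; of the three compounds, only compound 3 has the 3-cyanophenyl and 4-chlorophenyl groups together, and only compound 3 has the low number. Nothing measured here speaks to the reason for either step.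

The compounds shown leave open whether the nitrile itself is what counts or whether any group other than 3,5-difluorophenyl on the sulfonyl sulfur would do the same, as a plain phenyl, a 3-fluorophenyl or a 3-methoxyphenyl might show. They also leave open whether the 4-chlorophenyl can give way to a 4-fluorophenyl or a 4-methylphenyl on the aromatic carbon while the number stays as low.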